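Ester variation on compound 3: working notes

A few compounds are considered here, and "the series" means these few. Any claim that something is new, unique, unknown or untested is made for them only; others in the source may bear on it.

The series shares a core seen in compound 1 `CC1=C(C(=O)OC2CCCCC2)C(c2ccc3c(c2)OCCO3)C2=C(CC(C)(C)CC2=O)N1`, compound 2 `CC1=C(C(=O)OC2CCCCC2)C(c2cccc(C(F)(F)F)c2)C2=C(CC(C)(C)CC2=O)N1` and compound 3 `CC1=C(C(=O)OC2CCCCC2)C(c2cccc(Br)c2)C2=C(CC(C)(C)CC2=O)N1`, which differ only in the aryl group on a saturated ring carbon. In an assay on HEK293 cells for inhibition of neurogenic locus notch homolog protein 1 (Homo sapiens), read by a luciferase reporter and resazurin assay, with a stated time of 16 h (a lower number here means a stronger inhibitor, a higher number a weaker inhibitor), compound 1 gives 12300 nM, compound 2 gives 14700 nM and compound 3 gives 4150 nM. Compound 3 stands lowest of the three numbers: a 3.0-fold lower number from compound 1 to compound 3 (0.47 log units; beyond the scatter) and a 3.5-fold lower number from compound 2 to compound 3 (0.55 log units; beyond the scatter), whereas a 1.2-fold higher number from compound 1 to compound 2 (0.08 log units; within the scatter).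

Compound 4 `CC1=C(C(=O)OCc2ccc(C(C)(C)C)cc2)C(c2cccc(Br)c2)C2=C(CC(C)(C)CC2=O)N1` keeps the aryl group of compound 3 and changes the ester: 4-(tert-butyl)benzyl in place of cyclohexyl on an oxygen next to a carbonyl group. None of the three measured steps touches the ester; each alters the aryl group on the saturated ring carbon, so no measured step bears on this change and the ester has not been varied among these compounds. With no basis for a direction, the expectation for compound 4 relative to compound 3 is a 1.0-fold lower number from compound 3 to compound 4 (0.02 log units; within the scatter), no more than the scatter. The estimate for compound 4 in this assay is 4000 nM, with a range from 1000 nM to 16000 nM.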

Compound 4, half-maximal inhibitory concentration: 4270 nM
The estimate for compound 4 lay 1.1-fold (0.03 log units) below the measured number; low and high end bracket the measured number.
By their numbers in this assay, from the lowest: compounds 3 and 4 (each within the scatter of the next); then compounds 1 and 2 (each within the scatter of the next).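

In this assay, the ester position takes a large change with no shift in the read-out: 4-(tert-butyl)benzyl in place of cyclohexyl on an oxygen next to a carbonyl group gives a 1.0-fold higher number from compound 3 to compound 4 (0.01 log units; within the scatter). Among the compounds shown here, the entering group has 11 heavy atoms against 6 and an aromatic ring in place of a non-aromatic one, so this pair is the first evidence on the ester, and neither size nor ring type separates compound 3 from compound 4 here. Nothing available explains why the two esters read alike.

Open, on these data alone, is whether the same holds for a methyl ester, for an ester chain ending in an amine, or for a free carboxylic acid at this position. Also open, as far as these compounds go, is whether 4-(tert-butyl)benzyl behaves the same alongside the 3-(trifluoromethyl)phenyl group of compound 2.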